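From pyrrolidin-1-yl to cyclohexylamino on a sulfonyl sulfur

A few compounds are considered here, and "the series" means these few. Any claim that something is new, unique, unknown or untested is made for them only; others in the source may bear on it.

Compound 1 `CCCCCCNc1ccc([N+](=O)[O-])cc1S(N)(=O)=O` gives 6000 nM
Compound 2 `CCCCCCNc1ccc(C(=O)O)cc1S(=O)(=O)N(C)C` gives 243000 nM
Compound 3 `O=C(O)c1ccc(NCCCCCCCC(F)(F)F)c(S(=O)(=O)N2CCCC2)c1` gives 66000 nM

In a physicochemical assay for solubility, in phosphate buffer, measured as kinetic solubility, at pH 7.4, tested at 250 uM (a lower number here means a less soluble compound, a higher number a more soluble compound), compound 3 gives 66000 nM and so holds the middle of the three numbers. Compound 2 stands higher and compound 1 lower, and both gaps lie beyond the scatter. The next compound to be tested is compound 4 `O=C(O)c1ccc(NCCCCCCCC(F)(F)F)c(S(=O)(=O)NC2CCCCC2)c1` where cyclohexylamino sits in place of pyrrolidin-1-yl on a sulfonyl sulfur (cyclohexylamino in place of pyrrolidin-1-yl on a sulfonyl sulfur). Within the data shown here, no two of the measured compounds differ in one place only, so the data hold no measured step to guide this change. The expectation can therefore start only from compound 3 at 66000 nM and from the larger group that enters. A modest fall just beyond the scatter is expected in this assay as the estimated step (a 2.4-fold lower number from compound 3 to compound 4 (0.37 log units; beyond the scatter)). With so little to go on, the expected range is wide. Compound 4 is estimated at 28000 nM (range 8000 nM to 90000 nM).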

Compound 4, solubility: 9000 nM
Beside the measured number, compound 4's estimate is 3.1-fold (0.49 log units) above it; the range from low to high includes it.
By their numbers in this assay, from the lowest: compounds 1 and 4 (each within the scatter of the next); then compound 3; then compound 2.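

In this assay, with the rest of the molecule unchanged, cyclohexylamino in place of pyrrolidin-1-yl on a sulfonyl sulfur gives a 7.3-fold lower number from compound 3 to compound 4 (0.87 log units; beyond the scatter). Among these compounds, this is the first step in the set that can be read at one place, and it shows that the group on this sulfur can move the read-out beyond the scatter. The change alters more than one thing at once, a five-membered ring with a nitrogen giving way to a six-membered ring of carbon only and a hydrogen-bond donor entering, and no measurement at hand bears on what lies behind the step.

Cyclopentylamino or piperidin-1-yl on a sulfonyl sulfur would separate ring size from the donor. From the compounds shown here alone, whether the same change gives a like step with another chain on the shared core also remains open.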